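The source may report more compounds than this note shows. Statements on the series, on what has been measured and on what is new or still open speak of the compounds shown alone.

Compound 2, `COc1cc(C(=O)O)ccc1CN1CCC[C@H](OCc2cc(Cl)cc(Cl)c2)[C@@H]1c1ccccc1`, is the weaker of the two compounds measured in an assay on isolated protein for activation of cGMP-dependent protein kinase 1 (Homo sapiens), read by ADP-Glo, with stated times of 120 min and 40 min; on this read-out higher numbers stand for an effect only at larger amounts of compound and lower numbers for an effect already at smaller amounts: compound 2 gives 62000 nM, while compound 1, `COC(=O)Nn1c(C[C@H]2CCC[C@H](OCc3cc(C(F)(F)F)cc(C(F)(F)F)c3)[C@@H]2c2ccccc2)n[nH]c1=O`, gives 4500 nM, a gap that is beyond the scatter. Compound 1 and compound 2 differ in several places at once, so no single change between them can be read off.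

Compound 3, `Clc1cc(Cl)cc(CO[C@H]2CCCN(Cc3ccc(-c4nn[nH]n4)cc3)[C@H]2c2ccccc2)c1`, has not yet been measured. It differs from compound 2 by 4-(2H-tetrazol-5-yl)phenyl in place of 4-carboxy-2-methoxyphenyl on a saturated chain carbon bound to an amine nitrogen in a ring. The rest of the molecule, including the dichlorobenzyl ether and the phenyl group on the saturated ring, is unchanged.

Going by the values given here, no measured pair in this set isolates a change of this kind, so the expectation rests on the size of compound 2's value alone. For this assay, the step from a 1.4-fold lower number from compound 2 to compound 3 (0.14 log units; within the scatter) is expected to be small, most likely within the scatter, with the direction uncertain. Compound 3 is therefore estimated to give 45000 nM in this assay, within a range from 12000 nM to 160000 nM.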

Compound 3, half-maximal effective concentration: 74000 nM
For compound 3 the middle estimate is 1.6-fold (0.22 log units) below the measured one; low and high end bracket the measured number.
By their numbers in this assay, from the lowest: compound 1; then compounds 2 and 3 (each within the scatter of the next).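

In this assay, going by these compounds alone, the exchange gives a 1.2-fold higher number from compound 2 to compound 3 (0.08 log units; within the scatter) and so offers the first reading of a single place in this set. On a saturated chain carbon bound to an amine nitrogen in a ring, 4-(2H-tetrazol-5-yl)phenyl and 4-carboxy-2-methoxyphenyl cannot be told apart by this read-out, even though the carboxylic acid gives way to a tetrazole and the methoxy group is lost in the same step. No supporting evidence is available to explain this result.

Since the carboxy and methoxy groups leave together, the pair cannot show what either contributes alone, and the two contributions may or may not cancel. As far as these compounds go, it also remains open whether a primary amide, an amine or a sulfonamide on this phenyl ring, or a bare phenyl ring without any such group, would shift the number beyond the scatter, or whether this place responds little to changes of this kind.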